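A few compounds are considered here, and "the series" means these few. Any claim that something is new, unique, unknown or untested is made for them only; others in the source may bear on it.

Measured in a functional assay on A549 cells (Homo sapiens) for inhibition, read by sulforhodamine B assay, with a stated time of 74 h; on this read-out higher numbers stand for weaker inhibition and lower numbers for stronger inhibition:
- compound 1 `CS(=O)(=O)N1C(=O)COC12C=CC(=O)C=C2`: > 10000 nM, a limit
- compound 2 `O=C1C=CC2(C=C1)OCC(=O)N2S(=O)(=O)c1ccccc1`: > 10000 nM, a limit
- compound 3 `Cc1ccccc1S(=O)(=O)N1C(=O)COC12C=CC(=O)C=C2`: > 10000 nM, a limit

Compound 3 gives only a limit of > 10000 nM and no number. Going by the values given here, the whole series so far rests on (the limit of > 10000 nM in this assay, at which 3 of the 3 values shown sit).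

The next change leads to compound 4 `O=C1C=CC2(C=C1)OCC(=O)N2S(=O)(=O)c1ccc(Cl)cc1`, with 4-chlorophenyl in place of 2-methylphenyl on a sulfonyl sulfur.

Two measured changes fall at the same place on the sulfonyl sulfur: a step that the two limits leave unreadable from compound 1 to compound 2 and a step that the two limits leave unreadable from compound 1 to compound 3. The third bears on the aromatic group itself: a step that the two limits leave unreadable from compound 2 to compound 3. Among the compounds with values here, none of them supplies a size or a direction to carry over, and no compound yet has a numerical value. No step beyond the scatter is therefore expected in this assay, and compound 4 is expected most likely to be reported as a limit as well.

The expected change is a step that the limit leaves unreadable from compound 3 to compound 4.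

For compound 4 the estimate is 12000 nM, with an expected range of 3000 nM to 40000 nM.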

Compound 4, half-maximal inhibitory concentration: > 10000 nM
Compound 4: no number, only a limit; the forecaster's own chance of this, stated with the estimate: 75%; the middle value is on the limit's open side.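

In this assay compound 4 gives > 10000 nM, a limit. The steps to compound 4 from compound 1, compound 2 and compound 3 therefore cannot be read, and the series stays where it was: the limit of > 10000 nM in this assay, at which 4 of the 4 values shown sit.

The compounds shown leave open how far any group on the sulfonyl sulfur changes inhibition, in size or direction.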